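The source may report more compounds than this note shows. Statements on the series, on what has been measured and on what is new or still open speak of the compounds shown alone.

Measured compounds:
compound 1 `O=c1[nH]c2ccccc2n1CCCN1CCC(=C(c2ccccc2)c2ccccc2)CC1`: 2400 nM
compound 2 `Cc1ccc2ccn(CCCCN3CCN(C(c4ccccc4)c4ccccc4)CC3)c2c1`: 6500 nM

Of the compounds shown here, two have been tested in an assay on RPMI-8226 cells for antagonist activity at P2X purinoceptor 7 (Homo sapiens), read by calcium flux; on this read-out lower numbers stand for stronger inhibition and higher numbers for weaker inhibition. Compound 1 `O=c1[nH]c2ccccc2n1CCCN1CCC(=C(c2ccccc2)c2ccccc2)CC1` gives 2400 nM in this assay. Compound 2 `Cc1ccc2ccn(CCCCN3CCN(C(c4ccccc4)c4ccccc4)CC3)c2c1` gives 6500 nM in this assay, the higher of the two numbers; the gap to compound 1 lies beyond the usual scatter, so compound 2 is the weaker inhibitor of the pair. The two compounds differ in more than one place, so their values show only this ordering and nothing about any single change.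

Compound 3 `Fc1ccc2ccn(CCCCN3CCN(C(c4ccccc4)c4ccccc4)CC3)c2c1` is not yet measured. It differs from compound 2 in one place: fluoro in place of methyl on an aromatic carbon. Going by the values given here, no measured pair here carries this same change, so there is nothing in the data to set its size or direction. The swap of one small group for another of the same count on the aromatic ring is expected to move the number little, if at all; the step from compound 2 is estimated as a 1.1-fold lower number from compound 2 to compound 3 (0.03 log units; within the scatter), which is not expected to exceed the scatter. Compound 3 is therefore estimated to give about 6000 nM in this assay, within a range from 2500 nM to 15000 nM.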

Compound 3, half-maximal inhibitory concentration: 110 nM
The estimate for compound 3 lay 55-fold (1.74 log units) above the measured number, outside the stated range (below it).
By their numbers in this assay, from the lowest: compound 3; then compound 1; then compound 2.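

In this assay, fluoro in place of methyl on an aromatic carbon comes with a 59-fold lower number from compound 2 to compound 3 (1.77 log units; beyond the scatter), a large step that shows this position, meta to a fused ring and para to a fused ring, to be highly sensitive to the group it carries, which the earlier pair, differing in more than one place, could not reveal. The exchange leaves the counts of heavy atoms, rings, hydrogen-bond donors and hydrogen-bond acceptors unchanged and brings no net charge, so a change this small on those counts can still move the number far in this series. Nothing available here bears on why the number falls so far.

The compounds shown do not tell whether fluoro lowers the number or methyl raises it, and how chloro, methoxy or a plain hydrogen would stand on this aromatic carbon remains open. Going by these compounds alone, also open is whether the step would hold with a longer chain in place of the one shared by compound 2 and compound 3, or with a different group on the piperazine nitrogen.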